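Losing the fluorines at the assay limit

The compounds below may be only part of what the source reports. "The series", "measured", "known", "first", "only" and "open" are said of these compounds alone.

Values in an ADME assay on HepG2 cells (Homo sapiens) for inhibition, read by resazurin assay, with a stated time of 48 h (a higher number here means that more compound is needed for the effect, a lower number that less compound is needed), follow, each one a limit and not a number.

- Compound 1 `O=C(Nc1ccc2sc(-c3ccccc3)nc2c1)c1cccs1` gives > 50000 nM as a limit
- Compound 2 `O=C(Nc1ccc2sc(-c3ccccc3)nc2c1)N1CCCCC1` gives > 50000 nM as a limit
- Compound 3 `O=C(Nc1ccc2sc(-c3ccc(F)c(F)c3)nc2c1)N1CCCC1` gives > 50000 nM as a limit

Compound 3 therefore has no exact position on the scale, only the limit > 50000 nM in this assay as its mark. The change to compound 4 `O=C(Nc1ccc2sc(-c3ccccc3)nc2c1)N1CCCC1` is phenyl in place of 3,4-difluorophenyl on an aromatic carbon and amounts to phenyl in place of 3,4-difluorophenyl on an aromatic carbon.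

Little measured evidence bears on this change. Going by the values given here, the one measured step, a step that the two limits leave unreadable from compound 1 to compound 2, has no readable size, and it concerns a group on a carbonyl carbon, not this aromatic carbon. The broader picture is the limit of > 50000 nM in this assay, at which 3 of the 3 values shown sit, and no measured number lies inside that limit.

No step beyond the usual scatter is expected in this assay, in either direction, because compound 3 sits at the limit > 50000 nM and offers nothing firmer to move from. The estimated move is a number no higher from compound 3 to compound 4 (the limit leaves the size open) and it is expected to be unreadable or small. Compound 4 is expected near 50000 nM with an estimated range from 25000 nM to 100000 nM and most likely only a limit will be reported.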

Compound 4, half-maximal effective concentration: > 50000 nM
Compound 4 was reported as a limit; the forecaster's own chance of this, stated with the estimate: 85%; the middle value sits exactly at the limit.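

Going by these compounds alone, compound 4 is reported only as a limit, like compound 1, compound 2 and compound 3, so no step between any of them can be read: the limit of > 50000 nM in this assay, at which 4 of the 4 values shown sit. The compounds shown leave open how much of each is needed for the effect, and so whether phenyl and 3,4-difluorophenyl differ at all.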